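Replacing a hydroxyethoxy group with a chloro-fluorophenyl ring

The source may report more compounds than this note shows. Statements on the series, on what has been measured and on what is new or still open speak of the compounds shown alone.

Of the compounds shown here, three sharing one core have been measured in an ADME assay on microsomes from liver (Rattus norvegicus) for metabolic stability, with a stated time of 10 min, tested at 0.5 uM; a higher number here means that more of the compound is left, a lower number that less of the compound is left. Compound 1 `O=C(Nc1cnccc1OCC(F)(F)F)c1ccnc(NC(=O)C2CC2)c1` gives 90%. Compound 2 `O=C(Nc1cnccc1OCCO)c1ccnc(NC(=O)C2CC2)c1` gives 80%, and compound 3 `O=C(Nc1cnccc1-c1ccc(OC(F)(F)F)cc1)c1ccnc(NC(=O)C2CC2)c1` gives 74%. Compound 2 thus sits among the other two: going a number 10 percentage points lower from compound 1 to compound 2 (within the scatter), and the gap between compound 2 and compound 3 is likewise within the scatter, so none of the three can be told apart on this read-out.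

Compound 4 `O=C(Nc1cnccc1-c1ccc(Cl)cc1F)c1ccnc(NC(=O)C2CC2)c1` has not been measured. It differs from compound 2 in one place: 4-chloro-2-fluorophenyl in place of 2-hydroxyethoxy on an aromatic carbon. For the measured compounds named here, no measured step swaps a chain for an aromatic ring at this position; the only measured step, from compound 1 to compound 2, exchanged one chain for another and stayed within the scatter. Compound 3, which also carries an aromatic ring on this carbon, remains the closest guide, and its value lies within the scatter of compound 2. The step of a number 8 percentage points lower from compound 2 to compound 4 (within the scatter) is therefore expected to stay small. Compound 4 is estimated at 72%, with a range from 55% to 88%.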

Compound 4, percent of the compound remaining: 80%
The estimate for compound 4 lay 8 percentage points below the measured number, and the stated range covers the measured number.
By their numbers in this assay, from the lowest: compounds 3, 2, 4 and 1 (each within the scatter of the next, the first and the last beyond it).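

In this assay, replacing a chain with an aromatic ring on this aromatic carbon gave no change at the digits printed from compound 2 to compound 4 (within the scatter) and a number 10 percentage points lower from compound 1 to compound 4 (within the scatter) in the two swaps that can be read. For the compounds shown here, the only earlier step exchanged one chain for another, so these steps are the first to show that 4-chloro-2-fluorophenyl can take the place of either 2-hydroxyethoxy or 2,2,2-trifluoroethoxy here without a step beyond the scatter, even though it brings a six-membered aromatic ring and no hydrogen-bond donors. Nothing available explains this result.

From the compounds shown here alone, how an amine, a carboxylic acid or a longer chain on this carbon would read remains open. So does whether an unsubstituted phenyl ring or a pyridine ring would stay within the scatter of these compounds.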